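A few compounds are considered here, and "the series" means these few. Any claim that something is new, unique, unknown or untested is made for them only; others in the source may bear on it.

Measured compounds in an assay on NIH3T3 cells with melatonin receptor type 1B (Homo sapiens) as the target; on this read-out lower numbers stand for stronger inhibition and higher numbers for weaker inhibition:
compound 1 `CCC1Nc2cccc([C@@H]3C[C@H]3CNC(=O)C(C)C)c2O1`, 0.75 nM
compound 2 `CCCC1Nc2cccc([C@@H]3C[C@H]3CNC(=O)C(C)C)c2O1`, 0.28 nM
compound 3 `CC(=O)NC[C@@H]1C[C@H]1c1cccc2nc(CCCCc3ccccc3)oc12`, 0.37 nM

Compound 3 stands second highest of the three numbers; its value sits between those of compound 1 and compound 2, and the gap to compound 2 is within the scatter. Compound 4 `CCC(=O)NC[C@@H]1C[C@H]1c1cccc2nc(CCCCc3ccccc3)oc12` differs from compound 3 by methyl in place of hydrogen on a saturated chain carbon bound to a carbonyl carbon. Within the data shown here, the only measured step of a comparable kind is a 2.7-fold lower number from compound 1 to compound 2 (0.43 log units; beyond the scatter), a methyl entering on a different saturated chain carbon of the core side chain; it bears on the new step only loosely. A small lowering in this assay is therefore expected for compound 4, likely near the edge of the scatter, as a 1.5-fold lower number from compound 3 to compound 4 (0.17 log units; within the scatter). The estimate for compound 4 is 0.25 nM, in the range 0.12 nM to 0.6 nM.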

Compound 4, inhibition constant: 0.07 nM
Estimate against measurement, compound 4: 3.6-fold (0.55 log units) above, and the stated range ends above it.
By their numbers in this assay, from the lowest: compound 4; then compounds 2 and 3 (each within the scatter of the next); then compound 1.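

In this assay, the change from acetyl to propanoyl gives a 5.3-fold lower number from compound 3 to compound 4 (0.72 log units; beyond the scatter), so the saturated chain carbon bound to a carbonyl carbon is a position where one added methyl lowers the number beyond the scatter. Methyl in place of hydrogen now lowers the number at a second chain position, on a different core, and the two steps do not differ beyond the scatter: the same change on two cores in this assay, a 2.7-fold lower number (0.43 log units; beyond the scatter) from compound 1 to compound 2 and a 5.3-fold lower number (0.72 log units; beyond the scatter) from compound 3 to compound 4, 2.0-fold (0.30 log units) apart, within the scatter of two such steps

On these data alone, whether a longer chain or an amine on this carbon would lower the number further remains open. So does whether a branched chain here would keep the step.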